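This account rests on a few compounds, and the source may have more. Where it says the series, first, only, none or still open, it means among the compounds named here.

In a functional assay on cells (Neutrophil, Homo sapiens) for inhibition, with a stated time of 10 min (on this read-out higher numbers stand for weaker inhibition and lower numbers for stronger inhibition), compound 1 (`CCCC(O)Cn1ncc(C(=O)OCC)c1NC(=O)NC(C)C`) gives 1 nM, the highest of the three numbers measured. Compound 3 (`CCCC(O)Cn1ncc(C(=O)OCC)c1NC(=O)NCc1ccccc1`) gives 0.0032 nM and compound 2 (`CCOC(=O)c1cnn(CC(C)O)c1NC(=O)Nc1cccc2ccccc12`) gives 0.00097 nM, both lower beyond the scatter.

Compound 4 (`CCOC(=O)c1cnn(CC(C)O)c1NC(=O)NC(C)C`) keeps the isopropyl group of compound 1 and shortens the other chain, 2-hydroxypentyl to 2-hydroxypropyl: hydrogen in place of ethyl on a saturated chain carbon, two bonds along the chain from an oxygen on a saturated carbon.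

Going by the values given here, no measured step isolates this change. Among the compounds with values here, the one single-place step, a 310-fold lower number from compound 1 to compound 3 (2.49 log units; beyond the scatter), is large, but it concerns the amide-type nitrogen, so it shows only that this series can move widely in this assay. Compound 2 carries the same 2-hydroxypropyl chain and gives 0.00097 nM, so that chain is compatible with very low numbers, but compound 2 also differs from compound 4 on the amide-type nitrogen. Its value therefore says little about this change alone.

No clear direction is expected, and the expected step, a 1.4-fold lower number from compound 1 to compound 4 (0.15 log units; within the scatter), stays within the scatter, though with wide uncertainty. For compound 4 the estimate is 0.7 nM, with an expected range from 0.07 nM to 7 nM.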

Compound 4, half-maximal inhibitory concentration: 0.00082 nM
Compound 4: the middle estimate sits 850-fold (2.93 log units) above what was measured; measured number outside the range, below it.
By their numbers in this assay, from the lowest: compounds 4 and 2 (each within the scatter of the next); then compound 3; then compound 1.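

The chain is no silent position: with the isopropyl group held constant in this assay, 2-hydroxypropyl in place of 2-hydroxypentyl gives a 1200-fold lower number from compound 1 to compound 4 (3.09 log units; beyond the scatter) as a large step. Until now a step of this order stood only on the amide-type nitrogen, with a 310-fold lower number from compound 1 to compound 3 (2.49 log units; beyond the scatter) as the one case, and the saturated chain carbon two bonds along the chain from the oxygen now counts as a second place where the number moves widely. Nothing at hand gives a reason for this step.

As far as these compounds go, whether the shorter chain gives a similar step with benzyl on the amide-type nitrogen stays open. Also open, from the compounds shown here alone, is how the number responds to a chain of intermediate length, such as 2-hydroxybutyl, or to an amine in place of the hydroxyl group.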